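This account rests on a few compounds, and the source may have more. Where it says the series, first, only, none or still open, it means among the compounds named here.

Measured compounds: compound 1 `Cn1ccc2ccc(-c3cc(Nc4cnccc4C(=O)NCc4cncnc4)cc4nccnc34)cc21`, 106 nM; compound 2 `CN1CCC(NC(=O)c2ccncc2Nc2cc(-c3ccc4ccn(C)c4c3)c3nccnc3c2)CC1=O`, 41 nM; compound 3 `CC(=O)N1CC(CNC(=O)c2ccncc2Nc2cc(-c3ccc4ccn(C)c4c3)c3nccnc3c2)C1`, 137 nM, all in an assay for inhibition of 6-phosphofructo-2-kinase/fructose-2,6-bisphosphatase 3 (Homo sapiens), read by ADP-Glo, with a stated time of 2 h; on this read-out lower numbers stand for stronger inhibition and higher numbers for weaker inhibition.

Compound 3 carries the highest number of the three, yet the gap a 1.3-fold higher number from compound 1 to compound 3 (0.11 log units; within the scatter) lies within the scatter, while the gap a 3.3-fold higher number from compound 2 to compound 3 (0.52 log units; beyond the scatter) lies beyond it. Compound 4 `CC(=O)N1CCC(NC(=O)c2ccncc2Nc2cc(-c3ccc4ccn(C)c4c3)c3nccnc3c2)C1` differs from compound 3 by 1-acetylpyrrolidin-3-yl in place of (1-acetylazetidin-3-yl)methyl on an amide-type nitrogen. Both measured steps that changed the group on this amide nitrogen bear on it: a 1.3-fold higher number from compound 1 to compound 3 (0.11 log units; within the scatter) and a 3.3-fold higher number from compound 2 to compound 3 (0.52 log units; beyond the scatter) were within the scatter and modest. Neither replaces a four-membered ring on a chain by a five-membered ring bound directly, so only a small step is expected in this assay, in either direction or none. Compound 4 is therefore expected near 100 nM, between 45 nM and 220 nM, an expected step of a 1.4-fold lower number from compound 3 to compound 4 (0.14 log units; within the scatter).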

Compound 4, half-maximal inhibitory concentration: 105 nM
Compound 4: the middle estimate sits 1.1-fold (0.02 log units) below what was measured; the range from low to high includes it.
By their numbers in this assay, from the lowest: compound 2; then compounds 4, 1 and 3 (each within the scatter of the next).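

Within this assay the rearrangement of the same atoms from (1-acetylazetidin-3-yl)methyl to 1-acetylpyrrolidin-3-yl on the amide-type nitrogen gives a 1.3-fold lower number from compound 3 to compound 4 (0.12 log units; within the scatter) and so is not resolved by this read-out. The (pyrimidin-5-yl)methyl group and 1-acetylpyrrolidin-3-yl are not resolved either, with a 1.0-fold lower number from compound 1 to compound 4 (0.00 log units; within the scatter) between them. Only 1-methyl-2-oxopiperidin-4-yl stands apart from 1-acetylpyrrolidin-3-yl, with a 2.6-fold higher number from compound 2 to compound 4 (0.41 log units; beyond the scatter) on leaving it. Nothing available accounts for these steps. From the compounds shown here alone, whether an unacylated piperidin-4-yl amine or a carboxylic acid on this amide nitrogen would shift the number remains open.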